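This account rests on a few compounds, and the source may have more. Where it says the series, first, only, none or still open, it means among the compounds named here.

In a physicochemical assay for lipophilicity, using the shake flask method, measured as octanol-water partition, at pH 7.4 (on this read-out higher numbers stand for higher lipophilicity and lower numbers for lower lipophilicity), compound 1 `CC(=O)N[C@@H]1CCC[C@H](C(=O)Nc2cc(-c3cnc(C)n3C(C)C)ccn2)C1` gives 1.9, compound 2 `CC(=O)N[C@@H]1CCC[C@H](C(=O)Nc2cc(-c3cnn4c3CCCC4)c(Cl)cn2)C1` gives 3.2 and compound 3 `CC(=O)N[C@@H]1CCC[C@H](C(=O)Nc2cc(-c3cnc4ccccn34)c(Cl)cn2)C1` gives 3. Compound 3 therefore stands within the scatter of compound 2 and beyond the scatter above compound 1. Compound 4 `CC(=O)N[C@@H]1CCC[C@H](C(=O)Nc2cc(-c3cnn4c3CCCCC4)c(Cl)cn2)C1` carries a group of 10 heavy atoms (8 carbon, 2 nitrogen; one five-membered aromatic ring with 2 hetero atoms, one seven-membered non-aromatic ring with 1 hetero atom) in place of a group of 9 heavy atoms (7 carbon, 2 nitrogen; one five-membered aromatic ring with 2 hetero atoms, one six-membered aromatic ring with 1 hetero atom), on an aromatic carbon. Among the measured compounds shown here, one measured step bears on this change: a number 0.20 log units lower from compound 2 to compound 3 (within the scatter). That step exchanged a six-membered non-aromatic ring for a six-membered aromatic ring and stayed within the scatter, so ring aromaticity alone offers little guidance here. With a seven-membered non-aromatic ring entering and the heavy-atom count growing, a moderate rise in this assay is expected. The expected change is a number 0.50 log units higher from compound 3 to compound 4 (beyond the scatter). For compound 4 the estimated value is 3.5, within an expected range of 3.1 to 3.9.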

Compound 4, distribution coefficient: 3.6
The estimate for compound 4 lay 0.10 log units below the measured number; measured number inside the range.
By their numbers in this assay, from the lowest: compound 1; then compounds 3 and 2 (each within the scatter of the next); then compound 4.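

In this assay, the seven-membered non-aromatic ring at this position stands apart from both six-membered partners, with a number 0.60 log units higher from compound 3 to compound 4 (beyond the scatter) and with a number 0.40 log units higher from compound 2 to compound 4 (beyond the scatter). Among the compounds shown here, the earlier exchange of one six-membered ring for the other, a number 0.20 log units lower from compound 2 to compound 3 (within the scatter), gave no such separation, so this is the first change at this position that moves the read-out beyond the scatter. No available measurement accounts for the rise.

Going by these compounds, what a hydroxyl or an amine on the seven-membered ring would do remains open. So does whether the step holds without the chloro group.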